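The source may report more compounds than this note shows. Statements on the series, on what has been measured and on what is new or still open speak of the compounds shown alone.

Working notes on the series, read in a functional assay on MCF7 cells (Homo sapiens) for inhibition, read by sulforhodamine B assay; a lower number here means a stronger inhibitor of growth, a higher number a weaker inhibitor of growth. Compound 1 (`COc1ccc(-c2ccc(-c3ccc(-c4nc5cc(C)ccc5[nH]4)cc3)cc2)cc1OC`) gives 190 nM, compound 2 (`FC(F)(F)c1ccc(-c2ccc(-c3ccc(-c4nc5ccccc5[nH]4)cc3)cc2)cc1`) gives 41400 nM, and compound 3 (`Oc1cccc2[nH]c(-c3ccc(-c4ccc(-c5ccc(C(F)(F)F)cc5)cc4)cc3)nc12`) gives 2310 nM. Compound 3 thus stands in the middle of the three numbers, with compound 1 lower and compound 2 higher.

Compound 4 (`COc1ccc(-c2ccc(-c3ccc(-c4nc5c(O)cccc5[nH]4)cc3)cc2)cc1`) keeps the core of compound 3 and changes in one place: methoxy in place of trifluoromethyl on an aromatic carbon, para to a large group. Among the compounds with values here, the only measured step, an 18-fold lower number from compound 2 to compound 3 (1.25 log units; beyond the scatter), is hydroxy in place of hydrogen, so it does not test this change. Within the data shown here, no measured step isolates the swap. The nearest guide is compound 1, which carries methoxy rather than trifluoromethyl and gives 190 nM, although its core also differs. A moderate move to a lower number is therefore expected, with wide uncertainty. The expected step is a 3.9-fold lower number from compound 3 to compound 4 (0.59 log units; beyond the scatter). The estimate for compound 4 is 600 nM, with an expected range of 120 nM to 2500 nM.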

Compound 4, concentration for 50% growth inhibition: 3110 nM
Estimate against measurement, compound 4: 5.2-fold (0.71 log units) below; the whole stated range lies below it.
By their numbers in this assay, from the lowest: compound 1; then compounds 3 and 4 (each within the scatter of the next); then compound 2.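

Within the data shown here, this is the first measured step at this position: in this assay, 4-methoxyphenyl in place of 4-(trifluoromethyl)phenyl on the hydroxy-bearing core gives a 1.3-fold higher number from compound 3 to compound 4 (0.13 log units; within the scatter), so the two groups cannot be told apart here. Compound 1 differs from compound 4 in more than one place, so the methoxy it carries gives no separate reading of this swap. Nothing at hand accounts for the two groups reading alike.

Going by these compounds, it remains open whether the swap would read the same on the core of compound 2, which lacks the hydroxy, or whether the match holds only with that hydroxy present. On these data alone, it is also open how an amine, a carboxylic acid or a longer chain such as ethoxy would read on an aromatic carbon at this position.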